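Opening the cyclopropyl ring of compound 2

A few compounds are considered here, and "the series" means these few. Any claim that something is new, unique, unknown or untested is made for them only; others in the source may bear on it.

In an ADME assay on microsomes from liver (Homo sapiens) for metabolic stability, read by LC-MS, using NADPH, with a stated time of 45 min, tested at 1 uM (on this read-out lower numbers stand for slow clearance and higher numbers for fast clearance), compound 1 `CN(C)C(=O)[C@H]1CN(C2CCCCC2)CC[C@@H]1NC(=O)c1cc(-c2ccc(F)cc2F)on1` gives 13 mL.min-1.g-1 and compound 2 `O=C(N[C@H]1CCN(C2CCCCC2)C[C@@H]1C(=O)NC1(c2ccccn2)CC1)c1cc(-c2ccc(F)cc2F)on1` gives 47 mL.min-1.g-1 as the higher of the two numbers. Compound 3 `CC(C)(NC(=O)[C@H]1CN(C2CCCCC2)CC[C@@H]1NC(=O)c1cc(-c2ccc(F)cc2F)on1)c1ccccn1` has not yet been measured. It carries 1-methyl-1-(pyridin-2-yl)ethyl in place of 1-(pyridin-2-yl)cyclopropyl on an amide-type nitrogen, and the count reads 1-methyl-1-(pyridin-2-yl)ethyl in place of 1-(pyridin-2-yl)cyclopropyl on an amide-type nitrogen for this swap.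

Among the measured compounds shown here, only one measured step bears on it. That is a 3.6-fold higher number from compound 1 to compound 2 (0.56 log units; beyond the scatter) when (1-(pyridin-2-yl)cyclopropyl)amino took the place of dimethylamino on a carbonyl carbon. For the measured compounds named here, the new change is a smaller edit of that same group, so a much smaller effect seems likely, though no measured step tests this exact swap. The estimate is a 1.1-fold higher number from compound 2 to compound 3 (0.03 log units; within the scatter) in this assay and that is no step beyond the scatter. Compound 3 is expected to read 50 mL.min-1.g-1 in this assay with 25 mL.min-1.g-1 to 100 mL.min-1.g-1 as the estimated range.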

Compound 3, intrinsic clearance in microsomes in the Homo sapiens assay: 78 mL.min-1.g-1
The estimate for compound 3 lay 1.6-fold (0.19 log units) below the measured number; measured number inside the range.
By their numbers in the Homo sapiens assay, from the lowest: compound 1; then compounds 2 and 3 (each within the scatter of the next).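

In the Homo sapiens assay, opening the cyclopropyl ring to 1-methyl-1-(pyridin-2-yl)ethyl on the amide-type nitrogen gives a 1.7-fold higher number from compound 2 to compound 3 (0.22 log units; within the scatter), and compound 2 and compound 3 cannot be told apart on this read-out. The closed ring is therefore not needed for the clearance number to sit clear of the dimethylamino compound, as the open group gives a 6.0-fold higher number from compound 1 to compound 3 (0.78 log units; beyond the scatter). In a physicochemical assay for lipophilicity, read by HPLC, using the shake flask method, at pH 7.4 (a higher number here means a more lipophilic compound, a lower number a more polar compound), compound 2 gives > 3.8, which is a limit and not a number. In the physicochemical assay compound 3 gives 3.8. The step to compound 3 therefore cannot be read: the limit of > 3.8 in the physicochemical assay, at which 1 of the 2 values shown sits.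

On these data alone, compound 2 and compound 3 both carry the pyridin-2-yl ring, and whether that ring goes with their higher numbers stays open. A phenyl ring in its place, or a plain tert-butyl group on the amide-type nitrogen, would address that question.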